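A few compounds are considered here, and "the series" means these few. Any claim that something is new, unique, unknown or untested is made for them only; others in the source may bear on it.

- Compound 1 `CCOC(=O)c1c(-c2cccc(Cl)c2)[nH]c2cc(OC)c(F)cc2c1=O`: 105000 ng.h/mL
- Compound 2 `CCOC(=O)c1c(-c2cccc(Br)c2)[nH]c2cc(OC)c(F)cc2c1=O`: 67200 ng.h/mL

In an ADME assay on the whole organism (plasma, strain CD1) for pharmacokinetics, with Mus musculus as the target, at a dose of 200 mg/kg by the oral route (on this read-out higher numbers stand for higher exposure at the dose given and lower numbers for lower exposure), compound 2 gives 67200 ng.h/mL, and this cannot be told apart from compound 1 at 105000 ng.h/mL. Compound 3 `CCOC(=O)c1c(-c2cc(F)cc(OC)c2)[nH]c2cc(OC)c(F)cc2c1=O` has 3-fluoro-5-methoxyphenyl in place of 3-bromophenyl on an aromatic carbon. For the measured compounds named here, the only measured step that bears on this change is a 1.6-fold lower number from compound 1 to compound 2 (0.19 log units; within the scatter), with bromo in place of chloro. Going by the values given here, that step alters the same phenyl group, but no measured compound has a fluoro or methoxy group on that phenyl, so it is only a weak guide. No step beyond the scatter is therefore expected in this assay, in either direction. The expected step is a 1.0-fold higher number from compound 2 to compound 3 (0.02 log units; within the scatter). For compound 3 the estimated value is 70000 ng.h/mL, with an expected range from 20000 ng.h/mL to 200000 ng.h/mL.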

Compound 3, area under the concentration-time curve in the Mus musculus assay: 7400 ng.h/mL
Compound 3: the middle estimate sits 9.5-fold (0.98 log units) above what was measured; measured number outside the range, below it.
By their numbers in the Mus musculus assay, from the lowest: compound 3; then compounds 2 and 1 (each within the scatter of the next).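

In the Mus musculus assay compound 1 gives 105000 ng.h/mL and compound 2 gives 67200 ng.h/mL. The earlier compounds shown here showed only that, in the Mus musculus assay, bromo in place of chloro gives a 1.6-fold lower number from compound 1 to compound 2 (0.19 log units; within the scatter). The phenyl group at this position can matter far more: 3-fluoro-5-methoxyphenyl brings a 9.1-fold lower number from compound 2 to compound 3 (0.96 log units; beyond the scatter) and also a 14-fold lower number from compound 1 to compound 3 (1.15 log units; beyond the scatter) when set against the 3-chlorophenyl group. In a physicochemical assay for solubility, at pH 7.4 (a higher number here means a more soluble compound, a lower number a less soluble compound), compound 2 gives 7300 nM and compound 3 gives 7500 nM. In the physicochemical assay the same change gives only a 1.0-fold higher number from compound 2 to compound 3 (0.01 log units; within the scatter), and nothing measured here explains the fall in exposure.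

Fluoro and methoxy enter together, so the compounds shown do not tell which of them, or whether only the pair, goes with the lower exposure. On these data alone, a phenyl group carrying only one of them would separate the two, and how an amine or a carboxylic acid on that phenyl group would behave remains open.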